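The source may hold more compounds than are shown below. What is called first, only, known or untested is meant among the compounds shown, and "the series" means these compounds.

Measured compounds:
Compound 1, `c1ccc(COc2ccccc2Nc2ncnc3cc4c(cc23)OCCOCCO4)cc1`, gives > 100000 nM in a functional assay on HepG2 cells (Homo sapiens) for antiproliferative activity, read by MTT assay, with a stated time of 72 h (a higher number here means a weaker inhibitor, a lower number a stronger inhibitor), which is a limit of the assay and not a number.
Compound 2, `FC(F)(F)c1ccc(COc2ccccc2Nc2ncnc3cc4c(cc23)OCCOCCO4)cc1`, gives > 100000 nM in this assay, again a limit and not a number.
Compound 3, `FC(F)(F)c1ccc(COc2cccc(Nc3ncnc4cc5c(cc34)OCCOCCOCCO5)c2)cc1`, gives 34000 nM in this assay.

Compound 2 and compound 1 differ in one place only, (hydrogen in place of trifluoromethyl on an aromatic carbon). The step that the two limits leave unreadable from compound 2 to compound 1 cannot be sized because of the limit of > 100000 nM in this assay, at which 2 of the 3 values shown sit. The cores of compound 2 and compound 3 also differ, and that difference is not broken down here. Compound 4, `c1ccc(COc2cccc(Nc3ncnc4cc5c(cc34)OCCOCCOCCO5)c2)cc1`, is not yet measured. It differs from compound 3 by hydrogen in place of trifluoromethyl on an aromatic carbon, the same change as between compound 2 and compound 1, at a place described in identical words. Since the step that the two limits leave unreadable from compound 2 to compound 1 offers no readable size, the step of no change at the digits printed from compound 3 to compound 4 (within the scatter) is expected to be small but uncertain. Compound 4 is therefore estimated at 34000 nM in this assay, expected to fall between 12000 nM and 100000 nM.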

Compound 4, half-maximal inhibitory concentration: > 100000 nM
Compound 4 was reported as a limit; the forecaster's own chance of this, stated with the estimate: 35%; middle value at least 2.9-fold (0.46 log units) from the limit.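

In this assay, putting hydrogen in place of trifluoromethyl gives an at least 2.9-fold higher number from compound 3 to compound 4 (0.46 log units; beyond the scatter), so on this core the change weakens the compound. From the compounds shown here alone, on the core of compound 2, the same change cannot be read, since neither end of the step gives a number: the limit of > 100000 nM in this assay, at which 3 of the 4 values shown sit. Compound 4 also sits at a limit and not a number, so the full size of its step is unknown, and a single readable step cannot show whether the change carries from one core to the other.

The compounds shown leave open whether a different group in the same place, such as a methoxy group or a carboxylic acid, would match or improve on compound 3. They also leave open whether any group there would bring the core of compound 1 to a measurable number.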